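Urea to amide on a shared core: expected activity

A few compounds are considered here, and "the series" means these few. Any claim that something is new, unique, unknown or untested is made for them only; others in the source may bear on it.

Measured compounds:
compound 1, `O=C(Nc1cccc(-n2cc(-c3ccncc3)c(-c3cc(O)cc(Cl)c3)n2)c1)Nc1ccc(Cl)c(C(F)(F)F)c1`, 99% in a functional assay on HT-29 cells (Homo sapiens) for inhibition, read by sulforhodamine B assay, with a stated time of 48 h, tested at 1 uM; on this read-out higher numbers stand for a weaker effect at the one concentration tested and lower numbers for a stronger effect
compound 2, `COc1cc(Cl)cc(-c2nn(-c3cccc(NC(=O)Nc4ccc(Cl)c(C(F)(F)F)c4)c3)cc2-c2ccncc2)c1`, 55%

On these two numbers compound 2 stands lowest, that is, it shows the stronger effect; its nearest neighbour is compound 1, reached by a number 44 percentage points lower from compound 1 to compound 2 (beyond the scatter), a change in which a methyl replaces a hydrogen on an oxygen on an aromatic ring. Compound 3, `COc1cc(Cl)cc(-c2nn(-c3cccc(NC(=O)c4cccc(C(F)(F)F)c4)c3)cc2-c2ccncc2)c1`, is not yet measured. It differs from compound 2 in one place: 3-(trifluoromethyl)phenyl in place of (4-chloro-3-(trifluoromethyl)phenyl)amino on a carbonyl carbon. Going by the values given here, the only measured step, the methyl for hydrogen on the oxygen, concerns a different part of the molecule and tells nothing about what happens at the carbonyl carbon. Among the compounds with values here, no step bearing on this change has been measured, so the expectation rests on the value of compound 2 alone and must be wide. The loss of the hydrogen-bond donor and the chlorine is expected to weaken the effect somewhat, so a step of a number 15 percentage points higher from compound 2 to compound 3 (beyond the scatter) is estimated. Compound 3 is therefore expected to give about 70%, within a range from 45% to 100%.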

Compound 3, a percentage reported as activity, at one concentration (the size of the read-out at that concentration, not a potency): 70%
The estimate for compound 3 equals the measured number at the digits printed; the measured number falls inside the stated range.
By their numbers in this assay, from the lowest: compound 2; then compound 3; then compound 1.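

In this assay, the first change measured at the carbonyl carbon gives a number 15 percentage points higher from compound 2 to compound 3 (beyond the scatter), so the effect responds to this end of the molecule as well as to the methyl on the oxygen at the other end. Moving from a urea to an amide here takes away the amino nitrogen, with its hydrogen-bond donor, and the chlorine in a single step, and the effect weakens without being lost, since compound 3 reads 70% at the one concentration tested. Nothing in the available data explains this weakening, and a single step that removes both features cannot assign it to either one.

Still open, as far as these compounds go, is which of the two removed features matters more: a (3-(trifluoromethyl)phenyl)amino group or a 4-chloro-3-(trifluoromethyl)phenyl group on the carbonyl carbon would separate the amino nitrogen from the chlorine. Also open, from the compounds shown here alone, is whether the gain from the methyl on the oxygen carries over to the amide series, which a hydroxy counterpart of compound 3 would test.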